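A few compounds are considered here, and "the series" means these few. Any claim that something is new, unique, unknown or untested is made for them only; others in the source may bear on it.

Three compounds have so far been measured in an assay on isolated protein for inhibition of alpha-ketoglutarate-dependent dioxygenase alkB homolog 3 (Homo sapiens), read by polymerase chain reaction, with a stated time of 1 h; a higher number here means a weaker inhibitor, a lower number a stronger inhibitor:

Compound 1, `Cc1ccc2[nH]c(-n3[nH]c(C)c(Cc4ccccc4)c3=O)nc2c1`: 670 nM
Compound 2, `Cc1ccc2[nH]c(-n3[nH]c(C)c(Cc4ccc(C(F)(F)F)cc4)c3=O)nc2c1`: 570 nM
Compound 3, `Cc1ccc2[nH]c(-n3[nH]c(C)c(Cc4ccccc4Cl)c3=O)nc2c1`: 910 nM

All three share one core and differ only in what sits on the benzyl ring. Compound 3 gives the highest of the three numbers, yet both its gaps are small: the step of a 1.4-fold higher number from compound 1 to compound 3 (0.13 log units; within the scatter) and the step of a 1.2-fold lower number from compound 1 to compound 2 (0.07 log units; within the scatter) each stay within the scatter, so none of the three can be called the stronger or weaker inhibitor on this evidence.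

The next compound, compound 4, `Cc1ccc2[nH]c(-n3[nH]c(C)c(Cc4ccc(Cl)cc4)c3=O)nc2c1`, keeps every atom of compound 3 and only joins them differently: 4-chlorophenyl in place of 2-chlorophenyl on a saturated chain carbon bound to an aromatic carbon. The chlorine thus stays on the same ring but moves to another carbon of it.

For the measured compounds named here, two measured steps bear on this. Adding chloro to an aromatic carbon, as in a 1.4-fold higher number from compound 1 to compound 3 (0.13 log units; within the scatter), changed little, and adding trifluoromethyl to an aromatic carbon, as in a 1.2-fold lower number from compound 1 to compound 2 (0.07 log units; within the scatter), changed little in the other direction. Neither rearranging nor adding a small group on this ring has moved the number beyond the scatter, so compound 4 is expected to land close to compound 3, with at most a modest drift toward the lower numbers of compound 1 and compound 2: a 1.4-fold lower number from compound 3 to compound 4 (0.15 log units; within the scatter). The estimate for compound 4 is therefore 650 nM, within a range from 320 nM to 1300 nM.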

Compound 4, half-maximal inhibitory concentration: 750 nM
Compound 4: the middle estimate sits 1.2-fold (0.06 log units) below what was measured; the range from low to high includes it.
By their numbers in this assay, from the lowest: compounds 2, 1, 4 and 3 (each within the scatter of the next).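

Moving the chlorine from 2-chlorophenyl to 4-chlorophenyl on the saturated chain carbon gives a 1.2-fold lower number from compound 3 to compound 4 (0.08 log units; within the scatter) in this assay; this is the first pair shown with the same atoms joined differently, and on this evidence the two chlorine placements cannot be told apart. The 4-chlorophenyl compound also stays close to its neighbours when chloro replaces hydrogen on an aromatic carbon, a 1.1-fold higher number from compound 1 to compound 4 (0.05 log units; within the scatter), and when chloro replaces trifluoromethyl on an aromatic carbon, a 1.3-fold higher number from compound 2 to compound 4 (0.12 log units; within the scatter), so every step shown among these four compounds, which differ only on this ring, lies within the scatter. Nothing in the available evidence accounts for how little these changes alter the number.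

On these data alone, it remains open whether a quite different group on this ring, such as an amine or a carboxylic acid, would move the number beyond the scatter. Also open, as far as these compounds go, is whether a longer chain between the shared core and the ring, or a change to the shared core itself, would matter more than the ring changes seen so far.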